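Octyl chain in place of hydroxybutyl on the triazole-bearing series

The source may hold more compounds than are shown below. What is called first, only, known or untested is meant among the compounds shown, and "the series" means these compounds.

Measured so far:
Compound 1, `O=c1cc(Cn2cc(C3CC3)nn2)c2ccc(O)cc2o1`, gives > 100000 nM in a functional assay on HeLa cells (Homo sapiens) for inhibition, read by MTT assay, with a stated time of 72 h (a higher number here means a weaker inhibitor, a lower number a stronger inhibitor), which is a limit of the assay.
Compound 2, `O=c1cc(Cn2cc(CCCCO)nn2)c2ccc(O)cc2o1`, gives > 100000 nM in this assay, again a limit of the assay.

Compound 2 thus stands only at a limit in this assay, with no number of its own, as shown by the limit of > 100000 nM in this assay, at which 2 of the 2 values shown sit. Among the compounds with values here, the one step between measured compounds, a step that the two limits leave unreadable from compound 1 to compound 2, has no readable size. Compound 3, `CCCCCCCCc1cn(Cc2cc(=O)oc3cc(O)ccc23)nn1`, differs from compound 2 by butyl in place of hydroxy on a saturated chain carbon, four bonds along the chain from an aromatic carbon. Within the data shown here, no measured step touches a change of this kind, and neither value around the measured step is a number, so nothing measured fixes a direction or a size in this assay. The expected step is therefore an at least 1.2-fold lower number from compound 2 to compound 3 (0.09 log units; that floor lies within the scatter), with a further limit about as likely as a number. Compound 3 is estimated at 80000 nM in this assay, with a range from 15000 nM to 300000 nM.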

Compound 3, half-maximal inhibitory concentration: 35100 nM
Compound 3: middle estimate off by 2.3-fold (0.36 log units), on the high side; measured number inside the range.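

Within the data shown here, compound 3 is the only compound of the three with a number of its own in this assay and the other two sit at a limit of the assay: the limit of > 100000 nM in this assay, at which 2 of the 3 values shown sit.
Butyl in place of hydroxy on the saturated chain carbon gives an at least 2.8-fold lower number from compound 2 to compound 3 (0.45 log units; beyond the scatter) and octyl in place of cyclopropyl on the aromatic carbon gives an at least 2.8-fold lower number from compound 1 to compound 3 (0.45 log units; beyond the scatter) with both sizes being floors, as each step starts from a limit.
This position can therefore carry a group that gives a readable number, which cyclopropyl and 4-hydroxybutyl did not, while the step between those two cannot be read.

The compounds shown do not separate the effect of chain length from the loss of the hydroxy, which a plain butyl chain at this position would address.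
Going by these compounds, whether a longer chain such as decyl lowers the number further also stays open.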